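Methyl at the carbon beside the ring nitrogen: a second look

The source may hold more compounds than are shown below. What is called first, only, known or untested is meant among the compounds shown, and "the series" means these compounds.

Of the compounds shown here, three of one series have been measured in a functional assay (aorta) for inhibition, with Rattus norvegicus as the target; a higher number here means a weaker inhibitor, a lower number a stronger inhibitor. Compound 1, `CC(C)Nc1nc(O)c2cc(Cl)ccc2n1`, gives 17300 nM, and compound 2, `CCC(C)Nc1nc(O)c2cc(Cl)ccc2n1`, gives 13800 nM. These two differ by methyl in place of hydrogen on a saturated chain carbon, two bonds along the chain from a nitrogen on an aromatic ring, a change that moved the read-out by a 1.3-fold lower number from compound 1 to compound 2 (0.10 log units; within the scatter), so the two values are not told apart. Compound 3, `Oc1nc(NCc2ccccc2)nc2ccc(Cl)cc12`, gives 3200 nM, the lowest of the three numbers and beyond the scatter from both others; how its core differs from that of compound 1 is not broken down here.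

Compound 4, `C[C@@H](Nc1nc(O)c2cc(Cl)ccc2n1)c1ccccc1`, is not yet measured. It differs from compound 3 by methyl in place of hydrogen on a saturated chain carbon bound to an aromatic carbon and a nitrogen on an aromatic ring. Going by the values given here, this is the same kind of change as the one from compound 1 to compound 2, though not the same: there the methyl entered on a saturated chain carbon two bonds along the chain from a nitrogen on an aromatic ring, here it enters on a saturated chain carbon bound to an aromatic carbon and a nitrogen on an aromatic ring. Among the compounds with values here, the one earlier example gives only a small, within-scatter step, and the surroundings of the new site differ, so a wide range is expected. Compound 4 is expected to fall close to compound 3, with an estimated step of a 1.3-fold lower number from compound 3 to compound 4 (0.11 log units; within the scatter), because the earlier step of a 1.3-fold lower number from compound 1 to compound 2 (0.10 log units; within the scatter) was small. The estimate for compound 4 in this assay is 2500 nM, between 900 nM and 7000 nM.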

Compound 4, half-maximal inhibitory concentration: 2800 nM
For compound 4 the middle estimate is 1.1-fold (0.05 log units) below the measured one; measured number inside the range.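

In this assay, methyl in place of hydrogen on a saturated chain carbon bound to an aromatic carbon and a nitrogen on an aromatic ring gives a 1.1-fold lower number from compound 3 to compound 4 (0.06 log units; within the scatter), so the two compounds are not told apart. Set beside the earlier example, the change reads alike on the two cores, and in neither case does it move the read-out beyond the scatter: the same change on two cores in this assay, a 1.3-fold lower number (0.10 log units; within the scatter) from compound 1 to compound 2 and a 1.1-fold lower number (0.06 log units; within the scatter) from compound 3 to compound 4, 1.1-fold (0.04 log units) apart, within the scatter of two such steps

Going by these compounds alone, this agreement rests on only two pairs, with the methyl entering at a differently surrounded carbon in each, so it shows that the change was tolerated in these two cases but does not establish a rule for other cores. Nor can steps this small show whether the methyl has a slight effect or none at all in this assay.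

The compounds shown leave open whether the mirror-image form of compound 4 would give a value as close to that of compound 3. They also leave open whether something larger or of a different kind at the same carbon, such as a longer chain, an amine or a carboxylic acid, would be tolerated as well as methyl.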